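This account rests on a few compounds, and the source may have more. Where it says the series, first, only, none or still open, it means among the compounds named here.

The series shares one amide core, seen in compound 1 `CC(C)N(Cc1cccc(OCCCCCC(=O)O)c1)C(=O)c1ccc(-c2ccc3[nH]ccc3c2)cc1` and compound 2 `CCOC(=O)CCCCCOc1cccc(CN(C(=O)c2ccc(-c3cccc(OC)c3)cc2)C(C)C)c1`. The read-out is an ADME assay on Raji cells (Homo sapiens) for cytotoxicity, read by CellTiter-Glo and resazurin assay, with a stated time of 72 h; on this read-out lower numbers stand for an effect already at smaller amounts and higher numbers for an effect only at larger amounts of compound. In this assay compound 1 reaches only the limit > 26000 nM, so no number is known for it. In this assay compound 2 likewise gives only the limit > 21000 nM. On the numbers shown compound 2 therefore stands at the limit of > 21000 nM in this assay, at which 1 of the 2 values shown sits, and cannot be ranked against compound 1, whose value sits at the limit of > 26000 nM in this assay, at which 1 of the 2 values shown sits; both are limits, not measurements.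

Compound 3 `CCOC(=O)CCCCCOc1cccc(CN(C(=O)c2ccc(-c3ccc4[nH]ccc4c3)cc2)C(C)C)c1` differs from compound 2 in one place: 1H-indol-5-yl in place of 3-methoxyphenyl on an aromatic carbon. The same 1H-indol-5-yl group is already present in compound 1, which also ends in a limit. For the measured compounds named here, no measured pair isolates this change, so its size in this assay is not known from the data; compound 1 and compound 2 both sit at limits, and no movement beyond the scatter is expected in either direction. Compound 3 is therefore expected to return a limit as well, with the step that the limit leaves unreadable from compound 2 to compound 3 estimated as flat. The estimate for compound 3 in this assay is 30000 nM, within 12000 nM to 100000 nM.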

Compound 3, half-maximal effective concentration: > 26000 nM
Compound 3 ended at the assay's limit (the forecaster's own chance of this, stated with the estimate: 85%); the middle value lies beyond the limit too.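

Compound 3 gives only the limit > 26000 nM in this assay. Its steps from compound 2 and from compound 1 cannot be read, as all three compounds end in limits. The compounds shown leave open whether any member of the series has a measurable effect in this assay, and how large either change would be.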